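The source may report more compounds than this note shows. Statements on the series, on what has been measured and on what is new or still open speak of the compounds shown alone.

Compound 1 `S=C(N/N=C/c1ccc2ccccc2n1)Nc1ccc(Br)cc1` has been tested in a functional assay on HT-29 cells (Homo sapiens) for antiproliferative activity, read by sulforhodamine B assay, with a stated time of 72 h (a higher number here means a weaker inhibitor, a lower number a stronger inhibitor), where compound 1 gives 54400 nM. A second, related compound, compound 2 `Cc1ccc(NC(=O)N/N=C/c2ccc3ccccc3n2)cc1`, was run in this assay as well. In this assay compound 2 shows > 100000 nM, which is a limit of the assay rather than a number. So compound 1 holds the only plain number recorded, while the other entry sits at the limit of > 100000 nM in this assay, at which 1 of the 2 values shown sits. Compound 3 `Fc1ccccc1NC(=S)N/N=C/c1ccc2ccccc2n1` differs from compound 1 in one place: 2-fluorophenyl in place of 4-bromophenyl on an amide-type nitrogen. Going by the values given here, no measured pair isolates a change of this kind, so there is no measured step to lean on. The expected step from compound 1 to compound 3 is a 1.3-fold higher number from compound 1 to compound 3 (0.11 log units; within the scatter), small and within the usual scatter, with a weaker result judged somewhat more likely than a stronger one. Compound 3 is therefore estimated at 70000 nM in this assay, within a range from 25000 nM to 150000 nM.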

Compound 3, half-maximal inhibitory concentration: > 100000 nM
Compound 3 was reported as a limit; the forecaster's own chance of this, stated with the estimate: 35%; middle value at least 1.4-fold (0.15 log units) away from the limit.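

Going by these compounds alone, this is the first measured change on the aryl group at this position. Replacing 4-bromophenyl with 2-fluorophenyl on the amide-type nitrogen, whose other neighbour is the thiocarbonyl carbon, gives an at least 1.8-fold higher number from compound 1 to compound 3 (0.26 log units; that floor lies within the scatter), so this swap brings no gain in activity, although the printed floor alone does not establish a real loss. The result for compound 3 in this assay is a limit and not a number, and it is a limit now shared within this small set: the limit of > 100000 nM in this assay, at which 2 of the 3 values shown sit.

The swap changes both the halogen and its place on the ring, so this pair cannot show which of the two matters, if either does. Going by these compounds, how a plain phenyl, or a phenyl carrying an amine or a carboxylic acid, would behave on this nitrogen remains open.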